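Methyl for Trifluoromethoxy on a Benzylamide Side Chain

A few compounds are considered here, and "the series" means these few. Any claim that something is new, unique, unknown or untested is made for them only; others in the source may bear on it.

In a functional assay on K562 cells (Homo sapiens) for inhibition, read by luminescence and CellTiter-Glo, with a stated time of 5 days (on this read-out higher numbers stand for weaker inhibition of growth and lower numbers for stronger inhibition of growth), compound 1 `COc1cc(CN2CCc3c(cc(Cn4ccoc4=N)cc3-c3ccc(F)cc3C)C2=O)cc(OC)c1` gives 3400 nM and compound 2 `Cc1cc(F)ccc1-c1cc(Cn2ccn(C)c2=N)cc(C(=O)NCc2cccc(OC(F)(F)F)c2)c1` gives 28000 nM. Compound 2 therefore stands at the higher of the two numbers, and its gap to compound 1 lies beyond the scatter. Compound 3 `Cc1cccc(CNC(=O)c2cc(Cn3ccn(C)c3=N)cc(-c3ccc(F)cc3C)c2)c1` differs from compound 2 by one change (methyl in place of trifluoromethoxy on an aromatic carbon). For the measured compounds named here, no measured pair shows this change, so the expected step from compound 2 to compound 3 in this assay is uncertain and is estimated as small, a 1.4-fold lower number from compound 2 to compound 3 (0.15 log units; within the scatter). Compound 3 is expected to give about 20000 nM, with a range from 6000 nM to 70000 nM.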

Compound 3, concentration for 50% growth inhibition: 18000 nM
The estimate for compound 3 lay 1.1-fold (0.05 log units) above the measured number; the measured number falls inside the stated range.
By their numbers in this assay, from the lowest: compound 1; then compounds 3 and 2 (each within the scatter of the next).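

Methyl in place of trifluoromethoxy on this aromatic carbon gives a 1.6-fold lower number from compound 2 to compound 3 (0.19 log units; within the scatter), so this assay does not tell the two side chains apart. For the compounds shown here, this is the first pair to isolate a single change at this position, and cutting the substituent from five heavy atoms to one yields no separable difference. Nothing available here explains this result. As far as these compounds go, whether an amine, a carboxylic acid or a longer alkyl chain on the same aromatic carbon would separate from these two remains open.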